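Adding a Second Fluorine to a Carbamate Side Chain

A few compounds are considered here, and "the series" means these few. Any claim that something is new, unique, unknown or untested is made for them only; others in the source may bear on it.

Measured compounds:
Compound 1, `CC(C)=CCC/C(C)=C/CC1Cc2c(OCC=C(C)C)cc(=O)n(CCCO)c2CC1(C)C`: 30.3%
Compound 2, `CC(C)=CCC/C(C)=C/CC1Cc2c(OC(=O)Nc3ccc(F)cc3)cc(=O)n(CCCO)c2CC1(C)C`: 43.9%

Compound 1 is the simpler of the two measured compounds. In a functional assay on PANC-1 cells (Homo sapiens) for inhibition, read by MTT assay, with a stated time of 24 h, tested at 10 uM (a higher number here means more inhibition at the concentration tested (going by the name of the read-out), a lower number less inhibition), compound 1 gives 30.3%. Compound 2 carries a (4-fluorophenyl)carbamoyl group where compound 1 carries 3-methylbut-2-en-1-yl, and in this assay compound 2 gives 43.9%. That single swap gave a number 13.6 percentage points higher from compound 1 to compound 2 (beyond the scatter). Of the two numbers shown, compound 2 stands highest, with compound 1 as its only neighbour.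

Compound 3, `CC(C)=CCC/C(C)=C/CC1Cc2c(OC(=O)Nc3ccc(F)cc3F)cc(=O)n(CCCO)c2CC1(C)C`, has not yet been tested. It differs from compound 2 in one place: fluoro in place of hydrogen on an aromatic carbon. No measured step involves adding a fluoro group to an aromatic carbon; the only step shown, from compound 1 to compound 2, exchanges a whole group and cannot tell how a single added fluoro will behave. Among the measured compounds shown here, with no step that bears on this change, the expected step in this assay is a number 1.1 percentage points higher from compound 2 to compound 3 (within the scatter), a change not beyond the scatter in either direction. The estimate for compound 3 in this assay is therefore 45%, in a range from 30% to 60%.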

Compound 3, a percentage reported as inhibition, at one concentration (the size of the read-out at that concentration, not a potency): 33.7%
Compound 3: middle estimate off by 11.3 percentage points, on the high side, and the stated range covers the measured number.
By their numbers in this assay, from the lowest: compounds 1 and 3 (each within the scatter of the next); then compound 2.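

In this assay, one fluoro added to the (4-fluorophenyl)carbamoyl group, on the aromatic carbon ortho to a large group and meta to the existing fluoro group, gives a number 10.2 percentage points lower from compound 2 to compound 3 (beyond the scatter) and so shows that this single atom at this position can shift the read-out. The swap away from 3-methylbut-2-en-1-yl also reads differently with the new ring: with (2,4-difluorophenyl)carbamoyl in its place, the result is a number 3.4 percentage points higher from compound 1 to compound 3 (within the scatter) and the clear gain of the monofluorinated carbamoyl group is not retained, so that gain depends on what the aromatic ring carries. Nothing available explains why the added fluoro has this effect.

The compounds shown leave open whether the loss belongs to fluoro itself or would come with any group on this aromatic carbon, a question that a chloro, methyl or methoxy group there could help to settle. They also leave open how an unsubstituted phenyl ring, with no fluoro at all, would compare within the same carbamoyl group.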